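Side-chain exchange on the core of compound 1

The compounds below may be only part of what the source reports. "The series", "measured", "known", "first", "only" and "open" are said of these compounds alone.

Measured so far:
compound 1, `CSCC[C@H](NC(=O)CN(c1nc(Cl)nc2[nH]cnc12)C1CC1)C(=O)OCc1ccccc1`, gives 44.6% in a functional assay on the whole organism (Tail, strain ICR) with Mus musculus as the target, in the tail flick test, with a stated time of 90 min, at a dose of 25 umol/kg by the oral route; on this read-out higher numbers stand for a stronger effect at the one dose given and lower numbers for a weaker effect.
compound 2, `NC(=O)CC[C@H](NC(=O)CN(c1ncnc2c1ncn2C1CCCCO1)C1CC1)C(=O)OCc1ccccc1`, gives 37.8% in this assay.
compound 3, `C[C@H](NC(=O)CN(c1ncnc2c1ncn2C1CCCCO1)C1CC1)C(=O)OCc1ccccc1`, gives 32.1% in this assay.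

Compound 1 carries the highest number of the three; its gap to compound 2 is within the scatter, its gap to compound 3 beyond it. Compound 4, `NC(=O)CC[C@H](NC(=O)CN(c1nc(Cl)nc2[nH]cnc12)C1CC1)C(=O)OCc1ccccc1`, is to be measured in this assay. It differs from compound 1 in one place: carbamoyl in place of methylsulfanyl on a saturated chain carbon, three bonds along the chain from an amide-type nitrogen and a carbonyl carbon. For the measured compounds named here, the one measured step that bears on this change is a number 5.7 percentage points lower from compound 2 to compound 3 (within the scatter), which removes the carbamoylmethyl group on a different core and stays within the scatter. Compound 2, which carries the same carbamoyl-bearing chain that enters in compound 4, sits within the scatter of compound 1. Going by the values given here, no measured step exchanges methylsulfanyl for carbamoyl on the core of compound 1, so the direction is not fixed by the data. For compound 4 a step of a number 4.6 percentage points lower from compound 1 to compound 4 (within the scatter) is expected, not beyond the scatter. Compound 4 is estimated at 40%, between 28% and 52%.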

Compound 4, a percentage reported as activity, at one dose (the size of the read-out at that dose, not a potency): 42.8%
Compound 4: the middle estimate sits 2.8 percentage points below what was measured; measured number inside the range.
By their numbers in this assay, from the lowest: compounds 3, 2, 4 and 1 (each within the scatter of the next, the first and the last beyond it).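

In this assay, for the compounds shown here, the exchange of methylsulfanyl for carbamoyl on the core of compound 1 reads as a number 1.8 percentage points lower from compound 1 to compound 4 (within the scatter), the one step that isolates this change on this core. At this place, three bonds along the chain from an amide-type nitrogen and a carbonyl carbon, the assay therefore does not separate the 2-(methylsulfanyl)ethyl chain from the 2-carbamoylethyl chain, although the latter brings a hydrogen-bond donor. No measurement here offers an explanation for this result.

Open, from the compounds shown here alone, is whether a carboxylic acid, an amine or a longer chain at this place would give a step beyond the scatter on the core of compound 1. Also open, going by these compounds, is how the methyl side chain of compound 3 reads on that core.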